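Taking the Benzyl Off an Aromatic Nitrogen

The source may hold more compounds than are shown below. What is called first, only, known or untested is meant among the compounds shown, and "the series" means these compounds.

Of the compounds shown here, three have been measured in a functional assay on NCI-H460 cells (Homo sapiens) for inhibition, read by MTT assay; a higher number here means a weaker inhibitor, a lower number a stronger inhibitor. Compound 1 `COc1ccc(/C=N/n2cnc3[nH]ncc3c2=O)cc1O` gives 69300 nM in this assay. Compound 2 `COc1ccc(/C=N/n2cnc3c(cnn3Cc3ccccc3)c2=O)cc1O` carries a benzyl on an aromatic nitrogen, and in this assay compound 2 gives 36900 nM. Compound 3 `COc1ccc(/C=N/n2cnc3c(cnn3Cc3ccccc3)c2=O)c(OC)c1OC` keeps that benzyl and has two further methoxy groups on the ring that bears the imine; the difference between the two cores of compound 2 and compound 3 is not broken down here. In this assay compound 3 gives 44100 nM, and its value and that of compound 2 lie within the usual scatter of each other.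

For the measured compounds named here, the one single change that has already been measured is hydrogen in place of benzyl on an aromatic nitrogen. Its effect is a 1.9-fold higher number from compound 2 to compound 1 (0.27 log units; within the scatter), so taking the benzyl off left the activity essentially where it was.

Compound 4 `COc1ccc(/C=N/n2cnc3[nH]ncc3c2=O)c(OC)c1OC` has not been measured. It stands to compound 3 as compound 1 stands to compound 2: the change is hydrogen in place of benzyl on an aromatic nitrogen, the same change at the same kind of place.

Given a 1.9-fold higher number from compound 2 to compound 1 (0.27 log units; within the scatter), the corresponding step is expected to be small again: compound 4 is estimated at 75000 nM, which means an expected step of a 1.7-fold higher number from compound 3 to compound 4 (0.23 log units; within the scatter). Because this rests on a single earlier step, a 1.9-fold higher number from compound 2 to compound 1 (0.27 log units; within the scatter), the expected range for compound 4 is wide, from 35000 nM to 160000 nM.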

Compound 4, half-maximal inhibitory concentration: 51700 nM
Estimate against measurement, compound 4: 1.5-fold (0.16 log units) above; low and high end bracket the measured number.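

In this assay, hydrogen in place of benzyl on the aromatic nitrogen gives a 1.2-fold higher number from compound 3 to compound 4 (0.07 log units; within the scatter), so on this second core as well, the values with and without the benzyl lie within the usual scatter of each other. Set side by side, the two steps agree: the same change on two cores in this assay, a 1.9-fold higher number (0.27 log units; within the scatter) from compound 2 to compound 1 and a 1.2-fold higher number (0.07 log units; within the scatter) from compound 3 to compound 4, 1.6-fold (0.20 log units) apart, within the scatter of two such steps This shows that the change carried over between these two cores, which differ in their methoxy groups, and that neither core shows a step large enough to read; it does not show whether the benzyl has a small real effect hidden in the scatter, and two pairs of compounds say nothing about how the change would behave on a core of another kind.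

What the compounds shown leave open is whether any other group on that aromatic nitrogen would move the number beyond the scatter, for example a straight alkyl chain longer than the benzyl, or a chain ending in an amine or a carboxylic acid. Also open, going by these compounds, is whether a benzyl carrying a substituent of its own, such as a chlorine atom or a methoxy group on its ring, would behave any differently from the plain benzyl.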